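The source may hold more compounds than are shown below. What is called first, only, known or untested is meant among the compounds shown, and "the series" means these compounds.

Compounds measured:
Compound 1 `Cc1ccc(-c2cnnc(N3CCC(c4cccc([N+](=O)[O-])c4)C3)n2)o1`: in a physicochemical assay for solubility (a higher number here means a more soluble compound, a lower number a less soluble compound), compound 1 gives < 100000 nM, which is a limit of the assay, not a number.
Compound 2 `O=[N+]([O-])c1cccc(-c2ccc(-c3cnnc(N4CCC(c5cccc(Cl)c5)C4)n3)o2)c1`: in this assay compound 2 gives < 100000 nM, likewise a limit and not a number.

Among the measured compounds shown here, compound 2 therefore stands at the limit rather than at a measured point, and it shares that position with the only other measured compound, since (the limit of < 100000 nM in this assay, at which 2 of the 2 values shown sit). For the measured compounds named here, no step between two measured compounds exists in this set, so no measured size of change is available to lean on.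

Compound 3 `COC(=O)c1cccc(-c2ccc(-c3cnnc(N4CCC(c5cccc(Cl)c5)C4)n3)o2)c1` differs from compound 2 in one place: methoxycarbonyl in place of nitro on an aromatic carbon. Going by the values given here, the two limits say only that both measured compounds sit on the same side of the assay's boundary; they say nothing about how far.

Among the compounds with values here, with no measured step as a guide, compound 3 is expected to remain near where compound 2 sits, and the estimated change a step that the limit leaves unreadable from compound 2 to compound 3 is expected to be no more than the usual scatter. On that basis compound 3 is estimated at 50000 nM in this assay, within a range of 10000 nM to 100000 nM, with a fair chance that the assay again reports only a limit.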

Compound 3, solubility: < 100000 nM
Compound 3 ended at the assay's limit (the forecaster's own chance of this, stated with the estimate: 60%); the middle value does not contradict the limit.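

No step can be read from compound 2 to compound 3, since methoxycarbonyl in place of nitro leaves both compounds reported only as a limit and not as a number: the limit of < 100000 nM in this assay, at which 3 of the 3 values shown sit.

The compounds shown leave open how far compound 1, compound 2 and compound 3 each lie from that limit in this assay, and whether the two groups differ there at all.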